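Stomach series: compound 1 to compound 3, aryl to dimethylamino

A few compounds are considered here, and "the series" means these few. Any claim that something is new, unique, unknown or untested is made for them only; others in the source may bear on it.

Of the compounds shown here, two have been measured in a functional assay on the whole organism (stomach) with Rattus norvegicus as the target; a lower number here means that less compound is needed, a higher number that more compound is needed for the effect. Compound 1, `C/N=C(/NC#N)NCCCCn1nc(-c2ccc(Cl)cc2)ccc1=O`, gives 100 mg/kg in this assay, the highest of the two numbers seen so far. Compound 2, `NC(=O)SCCCCCN1NC=CC=C1c1ccccc1`, gives 23.8 mg/kg in this assay, and the gap between these two values lies beyond the usual scatter; the two structures differ in many places, so nothing about any single change can be drawn from them.

Compound 3, `C/N=C(/NC#N)NCCCCn1nc(N(C)C)ccc1=O`, has not yet been measured in this assay. It differs from compound 1 in one place: dimethylamino in place of 4-chlorophenyl on an aromatic carbon. Among the measured compounds shown here, no pair of measured compounds shows what this change does, so there is no direct guide to the size or direction of the step.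

For the measured compounds named here, with no measured step on which to rest, the change from compound 1 to compound 3 is expected to move the dose little, if at all, and the step of no change at the digits printed from compound 1 to compound 3 (within the scatter) is estimated to fall within the scatter. Compound 3 is therefore expected to give about 100 mg/kg in this assay, with a range from 40 mg/kg to 250 mg/kg.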

Compound 3, dose for half-maximal effect: > 100 mg/kg
Compound 3: only a limit was reported; the forecaster's own chance of this, stated with the estimate: 25%; the middle value sits exactly at the limit.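

In this assay compound 3 gives > 100 mg/kg, which is a limit of the assay and not a number. Among the compounds shown here, this is the first reading at this position, on an aromatic carbon next to the ring nitrogen: with dimethylamino in place of 4-chlorophenyl, the data show a number no lower from compound 1 to compound 3 (the limit leaves the size open), so the smaller, ring-free group brings no gain in dose here. The size of the step cannot be read, because the result stops at the assay limit: the limit of > 100 mg/kg in this assay, at which 1 of the 3 values shown sits.

For the compounds shown here, how far the number rises with dimethylamino stays open, and the single pair cannot separate the loss of the aromatic ring from the entry of the amine. Also open, from the compounds shown here alone, is whether an unsubstituted phenyl, a 4-methoxyphenyl or a smaller amine such as methylamino at this carbon, or a longer chain elsewhere on the shared core, would bring the dose under that of compound 1, which gives 100 mg/kg.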